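This account rests on a few compounds, and the source may have more. Where it says the series, first, only, none or still open, it means among the compounds named here.

Measured compounds:
Compound 1 `C[C@@]1(O)CC(=O)OC(CSc2nc(-c3ccccc3)c(-c3ccccc3)[nH]2)C1` — 170 nM
Compound 2 `Cn1c(SC[C@H]2C[C@@](C)(O)CC(=O)O2)nc(-c2ccccc2)c1-c1ccccc1.Cn1c(SC[C@H]2C[C@](C)(O)CC(=O)O2)nc(-c2ccccc2)c1-c1ccccc1` — 2600 nM
Compound 3 `CC1=CC(=O)OC(CSc2nc(-c3ccc(C)cc3)c(-c3ccc(C)cc3)[nH]2)C1` — 280 nM

In an assay on microsomes from liver for inhibition of sterol O-acyltransferase 1 (Rattus norvegicus) (a lower number here means a stronger inhibitor, a higher number a weaker inhibitor), compound 1 gives 170 nM, the lowest of the three numbers shown. Compound 3 at 280 nM sits within the scatter of that value, so no order between the two can be read. Compound 2 at 2600 nM lies well beyond the scatter and is the weaker of the pair with compound 1.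

Compound 4 `c1ccc(-c2nc(SCC3CCCCC3)[nH]c2-c2ccccc2)cc1` differs from compound 1 by a group of 6 heavy atoms (6 carbon; one six-membered non-aromatic ring of carbon only) in place of a group of 9 heavy atoms (6 carbon, 3 oxygen; one six-membered non-aromatic ring with 1 hetero atom), on a saturated chain carbon bound to a sulfur. Among the measured compounds shown here, no measured pair shows this change, so the expected step rests only on the structures. The loss of the hydroxyl and lactone oxygens is expected to cost some potency in this assay, beyond the scatter but not by a large margin. The step from compound 1 to compound 4 is expected to be a 3.5-fold higher number from compound 1 to compound 4 (0.55 log units; beyond the scatter). For compound 4 the estimate is 600 nM, with a range from 150 nM to 2500 nM.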

Compound 4, half-maximal inhibitory concentration: 100 nM
For compound 4 the middle estimate is 6.0-fold (0.78 log units) above the measured one, and the stated range ends above it.
By their numbers in this assay, from the lowest: compounds 4, 1 and 3 (each within the scatter of the next, the first and the last beyond it); then compound 2.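

Swapping the lactone-bearing ring of compound 1 for cyclohexyl, on the saturated chain carbon bound to a sulfur, gives a 1.7-fold lower number from compound 1 to compound 4 (0.23 log units; within the scatter) in this assay. At this position, therefore, a ring of carbon only, with no hydrogen-bond donors or acceptors and no defined stereocentre, gives a number within the scatter of the ring in compound 1. No evidence at hand accounts for this result.

Open, on these data alone, is whether an amine or a carboxylic acid on the cyclohexyl ring would keep the number in this range. The same question applies to a longer chain between the sulfur and the ring.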